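The compounds below may be only part of what the source reports. "The series", "measured", "known", "first", "only" and "open" are said of these compounds alone.

Measured so far in a functional assay on HCT-116 cells (Homo sapiens) for antiproliferative activity, read by CellTiter-Glo, with a stated time of 10 days; a lower number here means a stronger inhibitor, a higher number a weaker inhibitor
- compound 1 `COCc1cc(-c2cnn(C)c2-c2sc3ccccc3c2C#N)cc2c(CN)n[nH]c(=O)c12` gives 51 nM
- compound 2 `Cn1ncc(-c2cc(C(F)F)c3c(=O)[nH]nc(CN)c3c2)c1-c1sc2ccccc2c1C#N` gives 2030 nM

Going by the values given here, compound 2 has the higher of the two numbers, so it is the weaker inhibitor here, and compound 1 is its only neighbour. Compound 3 `CCOc1cc(-c2cnn(C)c2-c2sc3ccccc3c2C#N)cc2c(CN)n[nH]c(=O)c12` has ethoxy in place of difluoromethyl on an aromatic carbon, counted as ethoxy in place of difluoromethyl on an aromatic carbon on the shared core. Among the compounds with values here, one measured step bears on this change, as it also concerns the group on that carbon. Putting difluoromethyl in place of methoxymethyl gave a 40-fold higher number from compound 1 to compound 2 (1.60 log units; beyond the scatter) as a large loss of potency. Removing difluoromethyl should therefore move the number down, although this single step cannot show how ethoxy itself will behave. The expected change is a 17-fold lower number from compound 2 to compound 3 (1.23 log units; beyond the scatter) as a large estimated step. For compound 3 the estimated value is 120 nM with an expected range from 30 nM to 500 nM in this assay when measured.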

Compound 3, half-maximal inhibitory concentration: 637 nM
For compound 3 the middle estimate is 5.3-fold (0.72 log units) below the measured one, outside the stated range (above it).
By their numbers in this assay, from the lowest: compound 1; then compound 3; then compound 2.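

The group on this aromatic carbon now has three readings in this assay, and they form a graded order rather than a simple split between methoxymethyl and everything else. Ethoxy recovers only part of the potency lost with difluoromethyl, with a 3.2-fold lower number from compound 2 to compound 3 (0.50 log units; beyond the scatter) in the first comparison, while a 12-fold higher number from compound 1 to compound 3 (1.10 log units; beyond the scatter) in the second shows that it still falls well short of methoxymethyl, so two similarly sized groups that both contain oxygen are clearly not interchangeable here. Nothing measured alongside these numbers explains the order, so the reason for it remains unknown.

The three compounds leave open how a plain methoxy, a longer chain such as propoxy or an amine would behave on this carbon. They also cannot show whether any group here could improve on methoxymethyl.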